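From fluoro to bromo: a first estimate

The source may hold more compounds than are shown below. What is called first, only, known or untested is meant among the compounds shown, and "the series" means these compounds.

For the measured compounds named here, in a functional assay on MGC-803 cells (Homo sapiens) for inhibition, read by MTT assay, with a stated time of 72 h (on this read-out higher numbers stand for weaker inhibition and lower numbers for stronger inhibition), compound 2 (`O=C(Nc1cccc(F)c1)C1CCN(C/C=C/c2ccccc2)CC1`) stands at 23300 nM as the higher of the two numbers so far, and compound 1 (`O=C(Nc1cccc(C(F)(F)F)c1)C1CCN(C/C=C/c2ccccc2)CC1`) stands at 9590 nM as the lower. Compound 3 (`O=C(Nc1cccc(Br)c1)C1CCN(C/C=C/c2ccccc2)CC1`) carries bromo in place of fluoro on an aromatic carbon. Going by the values given here, the only measured step at this place is modest and beyond the scatter: a 2.4-fold higher number from compound 1 to compound 2 (0.39 log units; beyond the scatter) with fluoro in place of trifluoromethyl. Among the compounds with values here, with only this step as a guide, a similarly modest fall in the number is expected in this assay (a 1.9-fold lower number from compound 2 to compound 3 (0.29 log units; within the scatter)). Compound 3 is estimated at 12000 nM with an expected range of 6000 nM to 24000 nM on this read-out.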

Compound 3, half-maximal inhibitory concentration: 9110 nM
The estimate for compound 3 lay 1.3-fold (0.12 log units) above the measured number; low and high end bracket the measured number.
By their numbers in this assay, from the lowest: compounds 3 and 1 (each within the scatter of the next); then compound 2.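

At this place on the aromatic ring, a second group now differs from fluoro in this assay (a 2.6-fold lower number from compound 2 to compound 3 (0.41 log units; beyond the scatter)). Bromo and trifluoromethyl cannot be told apart (a 1.1-fold lower number from compound 1 to compound 3 (0.02 log units; within the scatter)), so among these three compounds fluoro alone stands apart, with the weakest inhibition. No measurement at hand accounts for this difference.

From the compounds shown here alone, whether a methoxy group, an amine or a carboxylic acid at this place would match bromo or fluoro remains open. Also open, going by these compounds, is whether a larger halogen, such as iodo, would go beyond bromo.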